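Swapping the aryl group on the core: compound 4

A few compounds are considered here, and "the series" means these few. Any claim that something is new, unique, unknown or untested is made for them only; others in the source may bear on it.

Measured compounds:
- compound 1, `CC1=C(C(=O)Nc2ccc([N+](=O)[O-])cc2)C(c2ccc(Br)cc2)N=C(SCc2ccccc2Cl)N1`: 7.7%
- compound 2, `CC1=C(C(=O)Nc2ccc([N+](=O)[O-])cc2)C(c2ccc(Br)cc2)N=C(SCc2ccc(Cl)cc2)N1`: 13.9%
- compound 3, `CC1=C(C(=O)Nc2ccc([N+](=O)[O-])cc2)C(c2ccc(Br)cc2)N=C(SCc2ccc(F)cc2)N1`: 12.9%

All three were tested in a functional assay on the whole organism (artery, strain albino) with Rattus norvegicus as the target, with a stated time of 120 min, at a dose of 10 mg/kg by the oral route; on this read-out lower numbers stand for less inhibition and higher numbers for more inhibition at the one dose given (going by the name of the read-out). Compound 1 gives 7.7%, the lowest of the three numbers, but its gaps to the others are small: a number 6.2 percentage points higher from compound 1 to compound 2 (within the scatter) and a number 5.2 percentage points higher from compound 1 to compound 3 (within the scatter), both within the scatter, so nothing can be said about an order among them. The same holds for a number 1 percentage points lower from compound 2 to compound 3 (within the scatter).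

Compound 4, `CC1=C(C(=O)Nc2ccc([N+](=O)[O-])cc2)C(c2cccc([N+](=O)[O-])c2)N=C(SCc2ccccc2Cl)N1`, is not yet measured. It differs from compound 1 in one place: 3-nitrophenyl in place of 4-bromophenyl on a saturated ring carbon

Going by the values given here, none of the measured steps touches this position; all three alter the aryl group carried by the (2-chlorobenzyl)sulfanyl chain, and each stayed within the scatter. There is therefore no measured guide to what a change on the saturated ring carbon does in this assay. Among the compounds with values here, the only anchor is the value of compound 1, 7.7%, together with the observation that every change seen so far left the read-out essentially unchanged.

On that basis the number for compound 4 is expected to stay near compound 1, with the step of a number 2.3 percentage points higher from compound 1 to compound 4 (within the scatter) not expected to exceed the scatter. The estimate for compound 4 is 10%, in the range 0% to 25%.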

Compound 4, a percentage reported as inhibition, in the whole organism at one dose (the size of the read-out at that dose, not a potency): 7.7%
For compound 4 the middle estimate is 2.3 percentage points above the measured one; low and high end bracket the measured number.
By their numbers in this assay, from the lowest: compounds 1, 4, 3 and 2 (each within the scatter of the next).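

Going by these compounds alone, putting 3-nitrophenyl in place of 4-bromophenyl on the saturated ring carbon gives no change at the digits printed from compound 1 to compound 4 (within the scatter) in this assay, and this is the first reading at this position, since the earlier steps all concerned the aryl group on the sulfur-bound chain. The group that enters is larger by the count of heavy atoms, 9 against 7, and it brings 2 hydrogen-bond acceptors where the group that leaves has none, yet the read-out at this single dose does not separate the two compounds. Nothing available explains why this swap leaves the number within the scatter, and a single pair cannot show whether other groups at this carbon would do the same.

Going by these compounds, whether a carboxylic acid or an amine on this phenyl ring, or a saturated cyclohexyl ring in its place, would move the number beyond the scatter remains open. Within the data shown here, also open is whether 3-nitrophenyl would behave the same way alongside the chains carried by compound 2 and compound 3, since here it is seen only with the (2-chlorobenzyl)sulfanyl group.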